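Pyridine for phenyl on the oxadiazole-linked thiazolidinedione

The source may hold more compounds than are shown below. What is called first, only, known or untested is meant among the compounds shown, and "the series" means these compounds.

Three compounds have been tested in a functional assay on the whole organism (strain Wistar) with Rattus norvegicus as the target, with a stated time of 15 days, at a dose of 3 mg/kg by the oral route; on this read-out higher numbers stand for a stronger effect at the one dose given and lower numbers for a weaker effect:

Compound 1 `Cc1nc(COc2ccc(/C=C3\SC(=O)NC3=O)cc2)cs1`: 18.6%
Compound 2 `O=C1NC(=O)/C(=C/c2ccc(OCCSc3nnc(-c4ccccc4[N+](=O)[O-])[nH]3)cc2)S1`: 19.8%
Compound 3 `O=C1NC(=O)/C(=C/c2ccc(OCCSc3nnc(-c4ccccc4)o3)cc2)S1`: 21.6%

Compound 3 holds the highest of the three numbers, but its gaps to compound 2 and to compound 1 are both within the scatter, so the three cannot be told apart on this assay. Among the compounds with values here, no step between two measured compounds that differ in one place is available to guide the next move.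

Compound 4 `O=C1NC(=O)/C(=C/c2ccc(OCCSc3nnc(-c4ccncc4)o3)cc2)S1` differs from compound 3 in one place: pyridin-4-yl in place of phenyl on an aromatic carbon. Within the data shown here, with no comparable step among the measured compounds, the expected step of a number 0.6 percentage points lower from compound 3 to compound 4 (within the scatter) is none beyond the scatter. Compound 4 is therefore estimated at 21%, with a range from 12% to 30%.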

Compound 4, a percentage reported as activity, at one dose (the size of the read-out at that dose, not a potency): 40.2%
For compound 4 the middle estimate is 19.2 percentage points below the measured one; measured number above the stated range.
By their numbers in this assay, from the lowest: compounds 1, 2 and 3 (each within the scatter of the next); then compound 4.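

In this assay, within the data shown here, pyridin-4-yl in place of phenyl gives a number 18.6 percentage points higher from compound 3 to compound 4 (beyond the scatter), the first step here that can be read for one change, and it shows that the group on this aromatic carbon can shift the read-out. The two groups have the same number of heavy atoms, and the entering ring has one nitrogen and one hydrogen-bond acceptor. Nothing available explains this step.

From the compounds shown here alone, whether pyridin-3-yl or pyridin-2-yl on the same carbon would match compound 4 remains open. So does whether pyrimidin-4-yl would go further.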